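The source may hold more compounds than are shown below. What is called first, only, known or untested is meant among the compounds shown, and "the series" means these compounds.

Values in an ADME assay on Vero cells (Chlorocebus sabaeus) for cytotoxicity, read by resazurin assay, with a stated time of 72 h (on this read-out higher numbers stand for weaker inhibition and lower numbers for stronger inhibition), so far

compound 1 `O=C(CCN1CCN(c2ccccc2F)CC1)c1ccc(F)cc1` gives 49500 nM
compound 2 `COc1ccc(N2CCN(CCC(=O)c3ccc(F)cc3)CC2)cc1` gives 31900 nM
compound 3 `O=C(CCN1CCN(c2ccc([N+](=O)[O-])cc2)CC1)c1ccc(F)cc1` gives 111000 nM

Compound 3, at 111000 nM, holds the highest number of the three. Compound 4 `O=C(CCN1CCN(c2ccc([N+](=O)[O-])cc2)CC1)c1ccc(F)c(F)c1` differs from it by fluoro in place of hydrogen on an aromatic carbon, ortho to a fluoro group, so that 4-fluorophenyl becomes 3,4-difluorophenyl: fluoro in place of hydrogen on an aromatic carbon.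

Two measured steps are available, a 1.6-fold lower number from compound 1 to compound 2 (0.19 log units; within the scatter) and a 3.5-fold higher number from compound 2 to compound 3 (0.54 log units; beyond the scatter). Only the second exceeds the scatter, and it does so modestly. Neither touches the 4-fluorophenyl group, so the series holds no direct evidence on a fluoro added there. No step beyond the scatter is therefore expected in this assay, and the expectation stays close to compound 3 at 111000 nM, with a slight lean towards a lower number. The expected step is a 1.2-fold lower number from compound 3 to compound 4 (0.09 log units; within the scatter). Compound 4 is estimated at 90000 nM, with an expected range from 45000 nM to 170000 nM as the likely outcome.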

Compound 4, half-maximal inhibitory concentration: 122000 nM
Estimate against measurement, compound 4: 1.4-fold (0.13 log units) below; low and high end bracket the measured number.
By their numbers in this assay, from the lowest: compounds 2 and 1 (each within the scatter of the next); then compounds 3 and 4 (each within the scatter of the next).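

In this assay, adding a fluoro to the 4-fluorophenyl group gives a 1.1-fold higher number from compound 3 to compound 4 (0.04 log units; within the scatter), so 4-fluorophenyl and 3,4-difluorophenyl read alike when the rest of the molecule carries the 4-nitrophenyl group. This is the first change shown on that ring, since the earlier steps all concerned the aromatic group on the amine nitrogen, and it indicates that the ring can take a second fluoro, ortho to the first, with no shift beyond the scatter. Nothing available here accounts for this result.

On these data alone, whether a chloro, a trifluoromethyl or an amine at the same place would read the same remains open. So does whether the added fluoro would behave alike in the company of the methoxy or the 2-fluorophenyl of the earlier compounds.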